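Shortening an ester side chain: compound 2 to compound 3

The compounds below may be only part of what the source reports. "The series", "measured", "known", "first", "only" and "open" are said of these compounds alone.

Compound 1 `CC(=O)O[C@H]1[C@@H](COC(=O)c2ccccc2)C[C@]2(OC(=O)/C=C/c3ccccc3)C(=O)/C(C)=C/[C@@H]3[C@H](CC[C@@]4(C)O[C@@H]4[C@@H]12)C3(C)C`: 28 ug/mL
Compound 2 `C=C1[C@@H](OC(=O)C(C)CC)[C@@H](OC(C)=O)C(=O)C(C)(C)/C=C/[C@H](C)[C@H](OC(=O)c2ccccc2)[C@@]2(O)C[C@H](C)[C@H](OC(C)=O)[C@@H]2[C@H]1OC(C)=O`: 17.6 ug/mL

Both numbers come from a functional assay on L5178 cells (Mus musculus) for antiproliferative activity, read by MTT assay, with a stated time of 72 h; on this read-out lower numbers stand for stronger inhibition and higher numbers for weaker inhibition. On the numbers shown compound 2 has the lowest value, with compound 1 as its nearest neighbour and within the scatter, so no order between the two can be claimed in this assay. Going by the values given here, no step between measured compounds that differ in one place is available, so the move to compound 3 `C=C1[C@@H](OC(=O)C(C)C)[C@@H](OC(C)=O)C(=O)C(C)(C)/C=C/[C@H](C)[C@H](OC(=O)c2ccccc2)[C@@]2(O)C[C@H](C)[C@H](OC(C)=O)[C@@H]2[C@H]1OC(C)=O` rests on the structural change alone. Compound 3 differs from compound 2 by hydrogen in place of methyl on a saturated chain carbon, two bonds along the chain from a carbonyl carbon. The change is small: one carbon leaves an ester chain, with no ring, no donor and no acceptor involved. The step from compound 2 to compound 3 in this assay is expected to be none beyond the scatter, in either direction, and the expected step is a 1.1-fold higher number from compound 2 to compound 3 (0.06 log units; within the scatter). Compound 3 is therefore estimated at 20 ug/mL, with a range from 10 ug/mL to 40 ug/mL.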

Compound 3, concentration for 50% inhibition in the L5178 assay: 12 ug/mL
Estimate against measurement, compound 3: 1.7-fold (0.22 log units) above; measured number inside the range.
By their numbers in the L5178 assay, from the lowest: compounds 3, 2 and 1 (each within the scatter of the next, the first and the last beyond it).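

Going by these compounds alone, in the L5178 assay, sec-butyl to isopropyl on this ester gives a 1.5-fold lower number from compound 2 to compound 3 (0.17 log units; within the scatter), the first one-place step, so removing one carbon at this position produces no change that can be read in this assay. In a physicochemical assay for lipophilicity (on this read-out higher numbers stand for higher lipophilicity and lower numbers for lower lipophilicity), compound 2 gives 4.5 and compound 3 gives 4. The same change therefore does register as a drop in lipophilicity, even though the antiproliferative read-out does not separate the pair: the measured partition coefficient of compound 2, 4.5, and of compound 3, 4, a number 0.50 log units lower (beyond the scatter)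

From the compounds shown here alone, whether the L5178 assay stays equally insensitive with a longer chain, an amine or a carboxylic acid on this ester remains open. A single step supports no trend with chain size, and compound 1 differs from compound 2 and compound 3 in more than one place, so it adds nothing about this position.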